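The compounds below may be only part of what the source reports. "The series", "measured", "known", "first", "only" and "open" are said of these compounds alone.

Measured compounds:
Compound 1 `CC(C)[C@H](NC(=O)COc1cccc2ccccc12)C(=O)N[C@@H](CC(=O)O)C(=O)COc1cc(C(F)(F)F)n(C)n1` gives 46000 nM in a functional assay on Jurkat cells (Homo sapiens) for inhibition; a lower number here means a stronger inhibitor, a higher number a weaker inhibitor.
Compound 2 `CCOC(=O)c1c(C)noc1OCC(=O)[C@H](CC(=O)O)NC(=O)[C@@H](NC(=O)COc1cccc2ccccc12)C(C)C` gives only a limit of this assay, > 200000 nM.
Compound 3 `CC(C)[C@H](NC(=O)COc1cccc2ccccc12)C(=O)N[C@@H](CC(=O)O)C(=O)CSc1ncc[nH]1` likewise gives only a limit of this assay, > 200000 nM.

Compound 3 therefore has no number of its own in this assay, only a limit, and that limit is shared by one other value shown here (the limit of > 200000 nM in this assay, at which 2 of the 3 values shown sit). Going by the values given here, the one step that leads to compound 3 is an at least 4.3-fold higher number from compound 1 to compound 3 (0.63 log units; beyond the scatter), which is read as at least modest; the parallel step an at least 4.3-fold higher number from compound 1 to compound 2 (0.63 log units; beyond the scatter) is of the same kind. Between compound 2 and compound 3 both values sit at the limit, so their order cannot be read.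

Compound 4 `CC(C)[C@H](NC(=O)COc1cccc2ccccc12)C(=O)N[C@@H](CC(=O)O)C(=O)CSC1=NCCS1` is the next compound, not yet measured. It differs from compound 3 by a group of 5 heavy atoms (3 carbon, 1 nitrogen, 1 sulfur; one five-membered non-aromatic ring with 2 hetero atoms) in place of a group of 5 heavy atoms (3 carbon, 2 nitrogen; one five-membered aromatic ring with 2 hetero atoms), on a sulfur. Among the compounds with values here, no measured step touches a change of this kind, so the only guide is where compound 3 stands, at the limit, and that two of three values shown sit there (the limit of > 200000 nM in this assay, at which 2 of the 3 values shown sit). The expected step is therefore a step that the limit leaves unreadable from compound 3 to compound 4, meaning no readable movement, with compound 4 most likely reporting a limit again. The estimate for compound 4 in this assay is 250000 nM, expected within 60000 nM to 1000000 nM.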

Compound 4, half-maximal inhibitory concentration: > 200000 nM
Compound 4: only a limit was reported; the forecaster's own chance of this, stated with the estimate: 70%; the middle value is on the limit's open side.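

Compound 4 places the first non-aromatic ring on the sulfur, and like the aromatic 1H-imidazol-2-yl of compound 3, it gives only a limit in this assay, not a number. Compared with the only compound that has a true number, the change gives an at least 4.3-fold higher number from compound 1 to compound 4 (0.63 log units; beyond the scatter), which is the same reading as for the steps to compound 2 and compound 3, so an aromatic ring on the sulfur is not the only group that ends up at the limit. The steps among compound 2, compound 3 and compound 4 cannot be read, as all three stand at one shared limit: the limit of > 200000 nM in this assay, at which 3 of the 4 values shown sit.

On these data alone, how far each of these three lies past the limit stays open, so the ring of compound 4 cannot be ranked against the 1H-imidazol-2-yl of compound 3. As far as these compounds go, compound 1 differs from compound 4 in both the linking atom and the ring, so the gap cannot be assigned to either one alone, and it is also open whether a phenyl ring or an amine-bearing chain on the sulfur would give a number at all.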